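Nitro to butyl on the benzamide of compound 2

A few compounds are considered here, and "the series" means these few. Any claim that something is new, unique, unknown or untested is made for them only; others in the source may bear on it.

Within the data shown here, compound 2 `O=C(O)c1cc(NC(=O)c2ccc([N+](=O)[O-])cc2)cc(C(=O)O)c1` stands highest of the two numbers so far in a functional assay on the whole organism (stomach) with Rattus norvegicus as the target (a lower number here means that less compound is needed, a higher number that more compound is needed for the effect), compound 2 giving 61.1 mg/kg. Compound 1 `O=C(Nc1ccc(-c2nn[nH]n2)cc1)c1cccc(-c2nn[nH]n2)c1` gives 0.6 mg/kg in this assay, a far lower number and beyond the scatter. Compound 3 `CCCCc1ccc(C(=O)Nc2cc(C(=O)O)cc(C(=O)O)c2)cc1` differs from compound 2 in one place: butyl in place of nitro on an aromatic carbon. Among the measured compounds shown here, no measured step of this kind exists, so its direction is open; a step of modest size, possibly none beyond the scatter, is expected, a 1.5-fold lower number from compound 2 to compound 3 (0.18 log units; within the scatter). Compound 3 is estimated at 40 mg/kg in this assay, with a range from 10 mg/kg to 150 mg/kg.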

Compound 3, dose for 50% inhibition: 91.9 mg/kg
Compound 3: middle estimate off by 2.3-fold (0.36 log units), on the low side; low and high end bracket the measured number.
By their numbers in this assay, from the lowest: compound 1; then compounds 2 and 3 (each within the scatter of the next).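

In this assay, exchanging nitro for butyl on the aromatic carbon para to a large group gives a 1.5-fold higher number from compound 2 to compound 3 (0.18 log units; within the scatter). Replacing a group carrying 2 hydrogen-bond acceptors with an all-carbon chain carrying none therefore leaves the number unchanged within the scatter, so this position accepts both groups on the shared core. No measurement at hand explains this result.

Still open, as far as these compounds go, is whether an amine, a hydroxyl or a longer chain at this position would move the number beyond the scatter. Also open, from the compounds shown here alone, is whether a smaller group, such as methyl, would behave like butyl and nitro.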